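A Chain in Place of a Ring on the Core

The compounds below may be only part of what the source reports. "The series", "measured", "known", "first", "only" and "open" are said of these compounds alone.

Measured compounds in a functional assay on HCT-116 cells (Homo sapiens) for cytotoxicity, read by MTT assay, with a stated time of 72 h; on this read-out higher numbers stand for weaker inhibition and lower numbers for stronger inhibition:
compound 1, `N[C@H]1CC[C@H](Nc2c(C(=O)NCc3ccc(Cl)cc3)nc(Br)c3cccnc23)CC1`: 4000 nM
compound 2, `CS(=O)(=O)Oc1c(C(=O)NCc2ccc(F)cc2)nc(Br)c2cccnc12`: > 20000 nM, a limit of the assay and not a number
compound 3, `N[C@H]1CC[C@H](Nc2c(C(=O)NCc3ccc(F)cc3)nc(Br)c3cccnc23)CC1`: 7000 nM

Compound 3 holds the highest of the two numbers given; compound 1 is nearest, and the step of a 1.8-fold higher number from compound 1 to compound 3 (0.24 log units; within the scatter) is small. Compound 2 stands at a limit of this assay (the limit of > 20000 nM in this assay, at which 1 of the 3 values shown sits). Going by the values given here, the step of an at least 2.8-fold lower number from compound 2 to compound 3 (0.45 log units; beyond the scatter) is the one change that moves the number beyond the scatter.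

Compound 4, `NCCCCCCNc1c(C(=O)NCc2ccc(F)cc2)nc(Br)c2cccnc12`, carries 6-aminohexyl in place of 4-aminocyclohexyl on a nitrogen on an aromatic ring. Among the compounds with values here, no measured step touches this exchange of a ring for a chain on the same nitrogen, so the expected step of a 1.1-fold higher number from compound 3 to compound 4 (0.06 log units; within the scatter) is none beyond the scatter. Compound 4 is therefore estimated at 8000 nM, with a range from 3000 nM to 25000 nM.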

Compound 4, half-maximal inhibitory concentration: 7000 nM
Compound 4: middle estimate off by 1.1-fold (0.06 log units), on the high side, within the range that was stated.
By their numbers in this assay, from the lowest: compounds 1, 3 and 4 (each within the scatter of the next). At a limit, above all of these: compound 2.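

In this assay, the open 6-aminohexyl chain takes the place of the 4-aminocyclohexyl ring on this nitrogen with no change at the digits printed from compound 3 to compound 4 (within the scatter), so among these compounds neither the ring nor its two defined stereocentres is required for this level of activity. The chain also keeps the separation from the (methylsulfonyl)oxy compound, with an at least 2.8-fold lower number from compound 2 to compound 4 (0.45 log units; beyond the scatter). That step is bounded on one side, as compound 2 stands at a limit and not a number: the limit of > 20000 nM in this assay, at which 1 of the 4 values shown sits.

Still open, as far as these compounds go, is how a shorter or longer chain would read, and whether a chain ending in a hydroxyl group or a carboxylic acid instead of the amine would give a similar number.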